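The compounds below may be only part of what the source reports. "The series", "measured", "known", "first", "only" and "open" are said of these compounds alone.

The measured compounds so far:

Compound 1 `CC(C)n1cnc2c(Nc3ccccc3)nc(NCOCc3ccc(/C=C/C(=O)Nc4ccccc4N)cc3)nc21`: 41%
Compound 2 `Nc1ccccc1NC(=O)c1ccc(Cn2cnc3c(Nc4ccccc4)nc(Cl)nc32)cc1`: 42.7%

Both compounds were tested in a functional assay on NCI-H460 cells (Homo sapiens) for antiproliferative activity, read by CCK-8 assay, with a stated time of 72 h, tested at 2 uM; on this read-out lower numbers stand for a weaker effect and higher numbers for a stronger effect at the one concentration tested. In this assay compound 1 gives 41%, and compound 2 gives 42.7%. Among the measured compounds shown here, compound 2 stands highest of the two numbers, but its nearest neighbour, compound 1, lies within the usual scatter of this kind of measurement, so the two values cannot be told apart; the two structures also differ in more than one place, so no single step connects them.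

Compound 3 `Nc1ccccc1NC(=O)c1ccc(Cn2cnc3c(Nc4cccc(OC(F)(F)F)c4)nc(Cl)nc32)cc1` has not yet been measured in this assay. It differs from compound 2 in one place: trifluoromethoxy in place of hydrogen on an aromatic carbon. For the measured compounds named here, no measured pair in this set shows what such a change does, so the expectation rests on compound 2 alone. The step of a number 2.3 percentage points higher from compound 2 to compound 3 (within the scatter) is expected to be small and not clearly beyond the scatter, in either direction. For compound 3 the estimate in this assay is 45%, with a range from 25% to 65%.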

Compound 3, a percentage reported as inhibition, at one concentration (the size of the read-out at that concentration, not a potency): 47.7%
For compound 3 the middle estimate is 2.7 percentage points below the measured one, within the range that was stated.
By their numbers in this assay, from the lowest: compounds 1, 2 and 3 (each within the scatter of the next).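

Among the compounds shown here, compound 3 gives the first view of a change at this place: in this assay, putting trifluoromethoxy in place of hydrogen, which turns the anilino group into (3-(trifluoromethoxy)phenyl)amino, gives a number 5 percentage points higher from compound 2 to compound 3 (within the scatter). A group of 5 heavy atoms on this aromatic carbon, meta to a large group, therefore leaves the read-out indistinguishable from that of the parent with plain hydrogen, so this single pair shows that the position can carry such a group without a clear loss of effect at the one concentration tested. No measurement at hand speaks to what lies behind this result.

Still open, on these data alone, is whether a different group on this carbon, such as an amine, a carboxylic acid or a longer alkyl chain, would produce a step that clears the scatter. A single pair tested at one concentration also cannot show whether the same swap would matter at other concentrations, since this read-out gives the size of the effect and not a potency.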